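Removing the methoxy from the pendant phenyl ring

A few compounds are considered here, and "the series" means these few. Any claim that something is new, unique, unknown or untested is made for them only; others in the source may bear on it.

Compound 2 `COc1ccc(-c2[nH]c3ccc(OC)cc3c2/C=C(\C#N)S(=O)(=O)c2ccccc2)cc1` gives 300 nM in a functional assay on CCRF-CEM cells (Homo sapiens) for cytotoxicity, read by MTT assay, with a stated time of 96 h; on this read-out lower numbers stand for an effect already at smaller amounts and higher numbers for an effect only at larger amounts of compound. It stands level with compound 1 `COc1ccc(-c2[nH]c3ccccc3c2/C=C(\C#N)S(=O)(=O)c2ccccc2)cc1`, which gives 300 nM; together they have the lowest numbers among the three measured compounds. Compound 3 `CCOC(=O)/C(=C/c1c(-c2ccccc2)[nH]c2ccccc12)C(=O)c1ccc([N+](=O)[O-])cc1`, built on a different core, gives 1800 nM, a number clearly higher than that of compound 2.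

Compound 4 `COc1ccc2[nH]c(-c3ccccc3)c(/C=C(\C#N)S(=O)(=O)c3ccccc3)c2c1` differs from compound 2 in one place: hydrogen in place of methoxy on an aromatic carbon. The place is an aromatic carbon of a six-membered aromatic ring of carbon only, para to a large group.

Among the compounds with values here, only one measured step speaks to this. Going no change at the digits printed from compound 1 to compound 2 (within the scatter), a methoxy was placed on a different aromatic carbon of the shared core, and the number did not move. Within the data shown here, that step concerns another position, so it is an imperfect guide, but it is the sole evidence on what a methoxy contributes here, and it says very little. The change to compound 4 is therefore expected to be no change at the digits printed from compound 2 to compound 4 (within the scatter), a step within the scatter, in no clear direction.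

Compound 4 is thus estimated at 300 nM, with a plausible range from 150 nM to 700 nM.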

Compound 4, half-maximal effective concentration: 1500 nM
Compound 4: middle estimate off by 5.0-fold (0.70 log units), on the low side, outside the stated range (above it).
By their numbers in this assay, from the lowest: compounds 1 and 2 (each within the scatter of the next); then compounds 4 and 3 (each within the scatter of the next).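

The step of a 5.0-fold higher number from compound 2 to compound 4 (0.70 log units; beyond the scatter) in this assay shows that the methoxy lost in going from 4-methoxyphenyl to phenyl counts at this place: the step lies beyond the usual scatter, and the higher number means that an effect appears only at a larger amount of compound. The earlier step of no change at the digits printed from compound 1 to compound 2 (within the scatter) lies within the scatter, so among these compounds a methoxy on one aromatic carbon says little about a methoxy on another, and the same group has to be judged place by place. Nothing measured here explains why the two places differ.

On these data alone, whether another group on this same aromatic carbon, such as an ethoxy, a hydroxyl or an amine, would keep the number of compound 2 or move it further remains open. Also open, as far as these compounds go, is whether removing this methoxy would have a step of the same size on the core of compound 1, which carries no second methoxy on its shared ring system.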